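Dichlorophenyl series: removal of one chloro, two cores

The source may hold more compounds than are shown below. What is called first, only, known or untested is meant among the compounds shown, and "the series" means these compounds.

Measured so far in a functional assay on A549 cells (Homo sapiens) for cytotoxicity, read by CCK-8 assay, with a stated time of 72 h; on this read-out lower numbers stand for stronger inhibition and higher numbers for weaker inhibition:
compound 1, `C=CCn1c(=O)/c(=C\c2cccc(Cl)c2)[nH]c(=O)/c1=C\c1ccccc1OC`, gives 5200 nM;
compound 2, `C=CCn1c(=O)/c(=C\c2cccc(Cl)c2Cl)[nH]c(=O)/c1=C\c1ccccc1OC`, gives 2300 nM;
compound 3, `COc1ccccc1/C=c1\c(=O)[nH]/c(=C/c2cccc(Cl)c2Cl)c(=O)n1C`, gives 200 nM.

Compound 4, `COc1ccccc1/C=c1\c(=O)[nH]/c(=C/c2ccccc2Cl)c(=O)n1C`, is not yet measured. Its core differs from the core of compound 1 and compound 2 by hydrogen in place of vinyl on a saturated chain carbon bound to an aromatic nitrogen; that change alone gave a 12-fold lower number from compound 2 to compound 3 (1.06 log units; beyond the scatter). The change to compound 4 is hydrogen in place of chloro on an aromatic carbon. The same change occurs once among the measured compounds, as hydrogen in place of chloro on an aromatic carbon, where it gave a 2.3-fold higher number from compound 2 to compound 1 (0.35 log units; beyond the scatter). The two places differ: in the measured pair the carbon is ortho to a large group, whereas in compound 4 it is meta to a large group, so this is the same kind of change rather than the same one. For compound 4 a modest step is expected, a 2.1-fold higher number from compound 3 to compound 4 (0.32 log units; beyond the scatter), because a 2.3-fold higher number from compound 2 to compound 1 (0.35 log units; beyond the scatter) was itself modest. Compound 4 is estimated at 420 nM, within 180 nM to 1000 nM.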

Compound 4, half-maximal inhibitory concentration: 300 nM
Estimate against measurement, compound 4: 1.4-fold (0.15 log units) above; the measured number falls inside the stated range.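

Taking the 2,3-dichlorophenyl of compound 3 to the 2-chlorophenyl of compound 4 gives a 1.5-fold higher number from compound 3 to compound 4 (0.18 log units; within the scatter). Set beside the earlier loss of a chloro, the two cores show no difference: the same change on two cores in this assay, a 2.3-fold higher number (0.35 log units; beyond the scatter) from compound 2 to compound 1 and a 1.5-fold higher number (0.18 log units; within the scatter) from compound 3 to compound 4, 1.5-fold (0.18 log units) apart, within the scatter of two such steps

This supports only a limited reading: across these two cores, removing one chloro gave steps of comparable size, but the chloro that leaves sits at a different place in each pair, so neither the transfer of one identical change nor its behaviour on any further core is shown. The compounds shown leave open how an amine, a nitrile or a carboxylic acid would compare with chloro on this ring. Also open, from the compounds shown here alone, is how a longer chain on the aromatic nitrogen would affect the values.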